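The source may hold more compounds than are shown below. What is called first, only, known or untested is meant among the compounds shown, and "the series" means these compounds.

Three related compounds have been tested in an ADME assay on MT4 cells (Homo sapiens) for cytotoxicity, read by MTT assay; a higher number here means that more compound is tolerated, a lower number that less compound is tolerated. Among the measured compounds shown here, compound 1 `COc1ccc(C(=O)CSc2nc(Cc3cccc4ccccc34)c(C(C)C)c(=O)[nH]2)cc1` gives 203000 nM, the only exact number of the three. Compound 2 `CCc1c(Cc2c(F)cccc2Cl)nc(SCC(=O)c2ccc(OC)cc2)[nH]c1=O` is reported only as a limit, > 11000 nM. Compound 3 `CC(C)c1c(Cc2c(F)cccc2Cl)nc(SCC(=O)c2ccc(F)cc2)[nH]c1=O` is also reported only as a limit, > 56000 nM. Compound 3 therefore stands on a limit and not on a number, which makes it a loose starting point.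

Compound 4 `COc1ccc(C(=O)CSc2nc(Cc3c(F)cccc3Cl)c(C(C)C)c(=O)[nH]2)cc1` differs from compound 3 in one place: methoxy in place of fluoro on an aromatic carbon. This is methoxy in place of fluoro on an aromatic carbon, para to a large group, so 4-fluorophenyl becomes 4-methoxyphenyl. For the measured compounds named here, no pair of measured compounds shows this change on its own. The nearest guide is compound 1, which carries the same 4-methoxyphenyl group and gives 203000 nM, so little sign of poor tolerance is expected from that group. The expected change, a step that the limit leaves unreadable from compound 3 to compound 4, is none beyond the scatter. For compound 4 the estimate is 70000 nM, with an expected range from 20000 nM to 200000 nM.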

Compound 4, half-maximal cytotoxic concentration: > 11000 nM
Compound 4 was reported as a limit (the forecaster's own chance of this, stated with the estimate: 55%); the middle value is on the limit's open side.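

In this assay compound 4 is reported only as a limit, > 11000 nM, so the steps to it from compound 1, compound 2 and compound 3 cannot be read. The compounds shown leave open whether 4-methoxyphenyl in place of 4-fluorophenyl changes how much compound is tolerated.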